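This account rests on a few compounds, and the source may have more. Where it says the series, first, only, none or still open, it means among the compounds named here.

Compound 1 `Cc1cc(Nc2cc(-c3ccccc3)[nH]n2)n2nc(SCCCc3ccccc3)nc2n1`: 5030 nM
Compound 2 `Cc1cc(Nc2cc(-c3ccccc3)[nH]n2)n2nc(SCCc3ccccc3)nc2n1`: 4930 nM
Compound 3 `Cc1cc(Nc2cc(-c3ccccc3)[nH]n2)n2nc(SCc3ccccc3Br)nc2n1`: 5630 nM

All three were tested in a functional assay on PC-9 cells (Homo sapiens) for inhibition, read by MTT assay, with a stated time of 72 h (on this read-out lower numbers stand for stronger inhibition and higher numbers for weaker inhibition), and their numbers sit close together. Compound 1 lies within the scatter of both neighbours: there is a 1.0-fold lower number from compound 1 to compound 2 (0.01 log units; within the scatter) and a 1.1-fold higher number from compound 1 to compound 3 (0.05 log units; within the scatter), while compound 2 and compound 3 differ by a 1.1-fold higher number from compound 2 to compound 3 (0.06 log units; within the scatter). On these numbers compound 1 is neither set apart from the others nor distinguishable from them.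

Compound 4 `CCCSc1nc2nc(C)cc(Nc3cc(-c4ccccc4)[nH]n3)n2n1` differs from compound 1 by hydrogen in place of phenyl on a saturated chain carbon, three bonds along the chain from a sulfur. Within the data shown here, none of the measured steps removes the aromatic ring; they only move it along the chain or substitute it, and each of those steps stayed within the scatter. That says the ring's exact position did not matter here, but it leaves open whether the ring itself matters. Among the measured compounds shown here, with no direct precedent, the expected step in this assay is a 1.3-fold higher number from compound 1 to compound 4 (0.11 log units; within the scatter), in the direction of a somewhat higher number but with a wide range. Compound 4 is therefore estimated at 6500 nM, expected to fall between 2500 nM and 17000 nM.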

Compound 4, half-maximal inhibitory concentration: > 50000 nM
Compound 4 gave a limit, no number (the forecaster's own chance of this, stated with the estimate: 10%); at least 7.6-fold (0.88 log units) between middle value and limit.
By their numbers in this assay, from the lowest: compounds 2, 1 and 3 (each within the scatter of the next). At a limit, above all of these: compound 4.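

Compound 4, with a plain propyl chain on the sulfur, gives a limit and not a number in this assay: the limit of > 50000 nM in this assay, at which 1 of the 4 values shown sits.

Taking away the phenyl gives an at least 9.9-fold higher number from compound 1 to compound 4 (0.99 log units; beyond the scatter), and the steps from the other two compounds are of similar size: an at least 8.8-fold higher number from compound 3 to compound 4 (0.94 log units; beyond the scatter) and an at least 10-fold higher number from compound 2 to compound 4 (1.00 log units; beyond the scatter). Among these four compounds, then, the place of the ring along the chain shifts nothing beyond the scatter, while having no ring at all on the chain clearly does.

As far as these compounds go, what remains open is whether the ring must be aromatic, as a cyclohexyl group on the same chain would show, or whether a longer plain chain such as hexyl, or an amine at the chain end, could replace it. The limit also leaves the true size of these steps unknown.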